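A few compounds are considered here, and "the series" means these few. Any claim that something is new, unique, unknown or untested is made for them only; others in the source may bear on it.

Among the measured compounds shown here, in a functional assay on HL-60 cells (Homo sapiens) for inhibition, read by MTT assay, with a stated time of 48 h (on this read-out lower numbers stand for stronger inhibition and higher numbers for weaker inhibition), compound 2 `C=C1C(=O)N(c2ccccc2)N(C)C1c1ccccc1` gives 40900 nM, and compound 1 `C=C1C(=O)N(c2ccccc2)N(C)C1c1ccc(OC)cc1` gives 37300 nM; the only measured step, a 1.1-fold higher number from compound 1 to compound 2 (0.04 log units; within the scatter), is within the scatter, so the two compounds stand together with no separation between them. Compound 3 `C=C1C(=O)N(c2ccccc2)N(C)C1CC` carries ethyl in place of phenyl on a saturated ring carbon. For the measured compounds named here, that measured step concerns an aromatic carbon, not the saturated ring carbon changed here, so no measured step bears on this change and its size or direction cannot be read from the data. The shift expected is a 1.2-fold higher number from compound 2 to compound 3 (0.09 log units; within the scatter), a cautious guess rather than a trend. Compound 3 is estimated at 50000 nM, with a range from 15000 nM to 200000 nM.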

Compound 3, half-maximal inhibitory concentration: 750000 nM
Compound 3: the middle estimate sits 15-fold (1.18 log units) below what was measured; the measured number lies above the stated range.
By their numbers in this assay, from the lowest: compounds 1 and 2 (each within the scatter of the next); then compound 3.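

In this assay, ethyl in place of phenyl on the saturated ring carbon gives an 18-fold higher number from compound 2 to compound 3 (1.26 log units; beyond the scatter) and so weakens inhibition clearly. Among the compounds shown here, this is the first change here that moves the number beyond the scatter, showing that this position, unlike the aromatic carbon changed earlier, responds to the group it carries. The data offer no explanation for the size of this loss.

Going by these compounds, whether the aromatic ring itself matters remains open, since a cyclohexyl group would test this directly. A longer chain such as butyl, or a benzyl group, could also show whether size alone tracks with inhibition.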